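Ring-nitrogen substituent series: phenyl to benzyl

This account rests on a few compounds, and the source may have more. Where it says the series, first, only, none or still open, it means among the compounds named here.

Measured compounds
Compound 1 `Cc1cc(NC(=O)Cn2nnc(-c3ccccc3)n2)n(C(C)C)n1` gives 556 nM in an assay on HEK293 cells for activation of Kir3.1/Kir3.2 (Homo sapiens), read by thallium flux; a higher number here means that more compound is needed for the effect, a lower number that less compound is needed.
Compound 2 `Cc1cc(NC(=O)Cn2nnc(-c3ccccc3)n2)n(C2CCS(=O)(=O)C2)n1` gives 1030 nM in this assay.
Compound 3 `Cc1cc(NC(=O)Cn2nnc(-c3ccccc3)n2)n(-c2ccccc2)n1` gives 3020 nM in this assay.

All three share one core and differ only in the group on an aromatic nitrogen of the five-membered aromatic ring with 2 nitrogen. Compound 3 gives the highest number of the three: a 2.9-fold higher number from compound 2 to compound 3 (0.47 log units; beyond the scatter) and a 5.4-fold higher number from compound 1 to compound 3 (0.73 log units; beyond the scatter). The two non-aromatic groups sit close together, since a 1.9-fold higher number from compound 1 to compound 2 (0.27 log units; within the scatter).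

Compound 4 `Cc1cc(NC(=O)Cn2nnc(-c3ccccc3)n2)n(Cc2ccccc2)n1` is the next member: benzyl in place of phenyl on an aromatic nitrogen. Going by the values given here, no measured pair swaps phenyl for benzyl, so the estimate rests on the two steps that brought phenyl in. Both raised the number beyond the scatter, so removing the direct aryl attachment and placing the ring one carbon away is expected to undo part of that rise in this assay, without a basis for reaching compound 1. Compound 4 is therefore expected to give 1300 nM, between 500 nM and 3200 nM, which amounts to an expected 2.3-fold lower number from compound 3 to compound 4 (0.37 log units; beyond the scatter).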

Compound 4, half-maximal effective concentration: 495 nM
Compound 4: middle estimate off by 2.6-fold (0.42 log units), on the high side; the measured number lies below the stated range.
By their numbers in this assay, from the lowest: compounds 4, 1 and 2 (each within the scatter of the next, the first and the last beyond it); then compound 3.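

In this assay, the phenyl of compound 3 proves to be a matter of attachment rather than of the ring alone: with a 6.1-fold lower number from compound 3 to compound 4 (0.79 log units; beyond the scatter) as the step for benzyl in place of phenyl, one added carbon changes the reading beyond the scatter, although both groups hold one six-membered aromatic ring of carbon only. This nitrogen therefore accepts such a ring when it is held through one carbon, since a 1.1-fold lower number from compound 1 to compound 4 (0.05 log units; within the scatter) leaves benzyl and isopropyl indistinguishable, while a 2.1-fold lower number from compound 2 to compound 4 (0.32 log units; beyond the scatter) separates benzyl from 1,1-dioxothiolan-3-yl, even though compound 1 and compound 2 lie within the scatter of each other. No accompanying measurement bears on why the added carbon has this effect.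

Still open, going by these compounds, is whether a longer chain such as phenethyl, or a benzyl ring carrying fluorine, a methoxy group, an amine or a carboxylic acid, stays level with compound 4 or moves towards compound 3. Also open, on these data alone, is whether the gap between benzyl and phenyl persists when the shared core changes elsewhere, for instance with an ethyl group in place of the methyl group.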